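The compounds below may be only part of what the source reports. "The series", "measured", "known", "first", "only" and "open" are said of these compounds alone.

The series shares the core of compound 2 `COc1cc(Cl)cc(-c2nn(-c3cccc(NC(=O)Nc4ccc(Cl)c(Cl)c4)c3)cc2-c2ccncc2)c1` and compound 1 `O=C(Nc1cccc(-n2cc(-c3ccncc3)c(-c3cc(O)cc(Cl)c3)n2)c1)Nc1ccc(Cl)c(Cl)c1`, which differ only by methyl in place of hydrogen on an oxygen on an aromatic ring. In a functional assay on SR cells (Homo sapiens) for inhibition, read by sulforhodamine B assay, with a stated time of 48 h, tested at 0.01 uM (a higher number here means a weaker effect of the compound at the concentration tested, a lower number a stronger effect), compound 1 gives 57% and compound 2 gives 94%; the change runs a number 37 percentage points higher from compound 1 to compound 2 (beyond the scatter), and compound 2 stands highest of the two numbers measured. Compound 3 `COc1cc(Cl)cc(-c2nn(-c3cccc(NC(=O)c4cccc(C(F)(F)F)c4)c3)cc2-c2ccncc2)c1` is not yet measured. It differs from compound 2 by 3-(trifluoromethyl)phenyl in place of (3,4-dichlorophenyl)amino on a carbonyl carbon. Among the compounds with values here, no measured step touches this part of the molecule: the only step known concerns the methyl in place of hydrogen on an oxygen on an aromatic ring, not the carbonyl carbon, so it gives no guide to direction. With no basis for a shift, compound 3 is expected to stay near compound 2 in this assay, at an estimated 88% with a range of 60% to 105%. The expected step is therefore a number 6 percentage points lower from compound 2 to compound 3 (within the scatter), none beyond the scatter, though the range is kept wide.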

Compound 3, a percentage reported as activity, at one concentration (the size of the read-out at that concentration, not a potency): 57%
Estimate against measurement, compound 3: 31 percentage points above; measured number outside the range, below it.
By their numbers in this assay, from the lowest: compounds 1 and 3 (each within the scatter of the next); then compound 2.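

In this assay, the group on the carbonyl carbon is not a silent part of the molecule: 3-(trifluoromethyl)phenyl in place of (3,4-dichlorophenyl)amino gives a number 37 percentage points lower from compound 2 to compound 3 (beyond the scatter), a large step that the earlier change on the oxygen could not have indicated. This single change alters two things together, as the leaving group carries an amino link with a hydrogen-bond donor and a dichlorinated ring, while the entering group has no such link and carries trifluoromethyl, so the step cannot be assigned to either. No data at hand explain the step.

Still open, from the compounds shown here alone, is whether the amino link or the ring substituents carry the step, and whether a carboxylic acid or an amine on the ring would be tolerated on this carbonyl carbon. Also open, going by these compounds, is how a hydroxyl in place of the methoxy group would read alongside 3-(trifluoromethyl)phenyl.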